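A few compounds are considered here, and "the series" means these few. Any claim that something is new, unique, unknown or untested is made for them only; others in the source may bear on it.

Measured so far:

Compound 1, `COc1cc(OC)c2c(=O)cc(-c3ccc(OCCN)cc3)oc2c1` — in a functional assay (Homo sapiens) for antiproliferative activity, read by resazurin assay, with a stated time of 48 h, tested at 20 uM (a lower number here means a weaker effect, a higher number a stronger effect of the compound at the concentration tested), compound 1 gives 70%.
Compound 2, `COc1cc(OC)c2c(=O)cc(-c3ccc(OCC(O)CO)cc3)oc2c1` — in this assay compound 2 gives 16%.

Among these two numbers compound 2 stands lowest; its nearest neighbour, compound 1, lies well above it, and the gap is beyond the scatter of repeated measurements.

Compound 3, `COc1cc(OC)c2c(=O)cc(-c3ccc(NCCN4CCCC4)cc3)oc2c1`, has not yet been measured. It differs from compound 2 as follows: (2-(pyrrolidin-1-yl)ethyl)amino in place of 2,3-dihydroxypropoxy on an aromatic carbon. Within the data shown here, the one measured step that bears on this change is a number 54 percentage points lower from compound 1 to compound 2 (beyond the scatter): there, a chain ending in an amine was replaced by a chain carrying two hydroxyls, and the read-out fell sharply. The change from compound 2 to compound 3 runs the other way, removing the hydroxyl-bearing chain and bringing in a chain that again ends in an amine, here within a five-membered ring and attached through a nitrogen rather than an oxygen. On that basis a large upward step is expected, a number 44 percentage points higher from compound 2 to compound 3 (beyond the scatter), though the new linking atom and ring leave the size of the gain uncertain. Compound 3 is therefore estimated at 60%, within a range from 35% to 85%.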

Compound 3, a percentage reported as inhibition, at one concentration (the size of the read-out at that concentration, not a potency): 80%
Compound 3: middle estimate off by 20 percentage points, on the low side, within the range that was stated.
By their numbers in this assay, from the lowest: compound 2; then compounds 1 and 3 (each within the scatter of the next).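

At this position on the aromatic ring, para to a large group, replacing 2,3-dihydroxypropoxy with (2-(pyrrolidin-1-yl)ethyl)amino gives a number 64 percentage points higher from compound 2 to compound 3 (beyond the scatter) in this assay, so the large difference seen earlier between compound 1 and compound 2 now appears with a second, different amine-bearing chain. Replacing 2-aminoethoxy with (2-(pyrrolidin-1-yl)ethyl)amino gives a number 10 percentage points higher from compound 1 to compound 3 (within the scatter), which means that this assay separates these two chains no more than repeated measurements would, even though the new chain differs in its linking atom, its size and its five-membered ring. Across these three compounds, then, both chains that carry an amine nitrogen sit well clear of the chain with two hydroxyls, and none of the three goes against this, although three compounds are a narrow base for any pattern.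

Compound 3 differs from compound 1 in both its link to the ring and its chain end, so the effect of each remains unseparated, and a 2-(pyrrolidin-1-yl)ethoxy chain would pull them apart, while a carboxylic acid at the chain end or a longer chain would test how far the trend extends. Nothing measured here explains why the read-out changes with these chains.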